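The compounds below may be only part of what the source reports. "The series", "measured", "known", "first", "only" and "open" are said of these compounds alone.

Measured so far:
Compound 1 `COc1cc(O)c(CC=C(C)C)c(O)c1C(=O)/C=C/c1ccc(O)c(O)c1`: 38100 nM
Compound 2 `COc1cc(/C=C/C(=O)c2c(OC)cc(O)c(CC=C(C)C)c2O)cc(OC)c1OC`: > 50000 nM

Among the measured compounds shown here, in a functional assay on HeLa cells (Homo sapiens) for inhibition, read by MTT assay, with a stated time of 72 h (on this read-out lower numbers stand for stronger inhibition and higher numbers for weaker inhibition), compound 1 gives 38100 nM, and this is the only true number available so far. Compound 2 is reported only as a limit, > 50000 nM.

The next compound to be tested is compound 3 `COc1cc(O)c(CC=C(C)C)c(O)c1C(=O)/C=C/c1cccc([N+](=O)[O-])c1`, which keeps the core of compound 1 but carries 3-nitrophenyl in place of 3,4-dihydroxyphenyl on a double-bonded chain carbon bound to a double-bonded chain carbon. The counted change is 3-nitrophenyl in place of 3,4-dihydroxyphenyl on a double-bonded chain carbon bound to a double-bonded chain carbon.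

For the measured compounds named here, no measured step covers this kind of replacement, so the expectation rests on compound 1 alone and is deliberately broad. The expected change in this assay, estimated as a 1.3-fold lower number from compound 1 to compound 3 (0.10 log units; within the scatter), is slightly toward stronger inhibition and no larger than the scatter. For compound 3 the estimated value is 30000 nM, with an expected range from 10000 nM to 70000 nM.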

Compound 3, half-maximal inhibitory concentration: 16500 nM
Estimate against measurement, compound 3: 1.8-fold (0.26 log units) above; the range from low to high includes it.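

In this assay, the position on a double-bonded chain carbon bound to a double-bonded chain carbon now has its first readable step: 3-nitrophenyl in place of 3,4-dihydroxyphenyl gives a 2.3-fold lower number from compound 1 to compound 3 (0.36 log units; beyond the scatter). Inhibition at this position therefore does not depend on keeping 3,4-dihydroxyphenyl, since the entering group, with 0 hydrogen-bond donors against 2 in the group it replaces, gives the lower number. Nothing measured here gives a reason for this step.

A single replacement cannot separate the gain from adding the nitro group from the effect of removing the two hydroxyl groups. From the compounds shown here alone, whether an amine or a carboxylic acid on the same phenyl ring would shift the number in the same direction remains open, as does whether the step would hold on a changed core.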